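The source may hold more compounds than are shown below. What is called first, only, known or untested is meant among the compounds shown, and "the series" means these compounds.

Compound 1 `COc1ccc(-c2cnc(NC(=O)c3ccc(Br)cc3)n2C)cc1` was examined in a toxicity assay on THP-1 cells (Homo sapiens) for inhibition; on this read-out higher numbers stand for lower toxicity in this test and lower numbers for higher toxicity in this test. Compound 1 gives > 100000 nM, which is a limit of the assay rather than a number, as the limit of > 100000 nM in this assay, at which 1 of the 3 values shown sits, records. Compound 2 `Cn1cc(-c2ccccc2)nc1NC(=O)c1ccc(F)cc1` in this assay reaches > 50000 nM, again a limit, as the limit of > 50000 nM in this assay, at which 1 of the 3 values shown sits, records. Compound 3 `Cc1ccc(C(=O)Nc2ncc(-c3ccccc3)o2)cc1` gives 26000 nM in this assay. Among the measured compounds shown here, no two of these three compounds differ in only one place, so no measured step is available. Compound 4 `COc1ccc(-c2cnc(NC(=O)c3ccccc3F)n2C)cc1` differs from compound 1 by the change (2-fluorophenyl in place of 4-bromophenyl on a carbonyl carbon). Because compound 1 sits at > 100000 nM, compound 4 is expected to show no step beyond the scatter, the estimated step being a number no higher from compound 1 to compound 4 (the limit leaves the size open). Compound 4 is therefore estimated at 100000 nM, with a range from 40000 nM to 200000 nM.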

Compound 4, half-maximal cytotoxic concentration: > 100000 nM
Compound 4 ended at the assay's limit; the forecaster's own chance of this, stated with the estimate: 70%; the middle value lies on the limit itself.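

The step between compound 1 and compound 4 cannot be read: both compounds stand at a limit of this assay. The compounds shown leave open what 2-fluorophenyl in place of 4-bromophenyl does to the read-out.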